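Shifting the methyl on the thiophene of compound 3

The source may hold more compounds than are shown below. What is called first, only, known or untested is meant among the compounds shown, and "the series" means these compounds.

The three measured compounds are:
compound 1 `Cc1ccsc1/C=C(/SCc1ccc(F)cc1)C(=O)c1ccc(Br)cc1`, which in a functional assay on DU-145 cells (Homo sapiens) for inhibition, read by trypan blue exclusion, with a stated time of 96 h (on this read-out lower numbers stand for stronger inhibition of growth and higher numbers for weaker inhibition of growth), gives 50000 nM;
compound 2 `Cc1ccsc1/C=C(/SCc1ccc(Cl)cc1)C(=O)c1ccc(Br)cc1`, which in this assay gives 25000 nM;
compound 3 `Cc1ccc(S/C(=C/c2sccc2C)C(=O)c2ccc(Br)cc2)cc1`, which in this assay gives 50000 nM.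

Compound 3 stands level with compound 1 at the digits printed, and together they hold the highest of the three numbers; its furthest neighbour is compound 2, the difference being a 2.0-fold higher number from compound 2 to compound 3 (0.30 log units; within the scatter), which stays within the scatter. All three numbers lie within the scatter of one another.

Compound 4 `Cc1ccc(S/C(=C/c2ccc(C)s2)C(=O)c2ccc(Br)cc2)cc1` differs from compound 3 in one place: 5-methylthiophen-2-yl in place of 3-methylthiophen-2-yl on a double-bonded chain carbon bound to a double-bonded chain carbon. The measured steps, a 2.0-fold lower number from compound 1 to compound 2 (0.30 log units; within the scatter) and no change at the digits printed from compound 1 to compound 3 (within the scatter), both concern the group on the sulfur or the halogen on its ring, and none of them touches the thiophene. No measured step therefore bears directly on this change, and the measured numbers give no reason to expect a step beyond the scatter.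

The step from compound 3 to compound 4 is expected to be no change at the digits printed from compound 3 to compound 4 (within the scatter). Compound 4 is expected to give about 50000 nM in this assay, within a range from 20000 nM to 120000 nM.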

Compound 4, concentration for 50% growth inhibition: > 100000 nM
Compound 4 ended at the assay's limit; the forecaster's own chance of this, stated with the estimate: 20%; middle value at least 2.0-fold (0.30 log units) from the limit.
By their numbers in this assay, from the lowest: compounds 2, 1 and 3 (each within the scatter of the next). At a limit, above all of these: compound 4.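

In this assay compound 4 gives > 100000 nM, which is a limit of the assay and not a number. Moving the methyl gives an at least 2.0-fold higher number from compound 3 to compound 4 (0.30 log units; that floor lies within the scatter); this is the only step shown that touches the thiophene, and with the same atoms joined differently it points towards weaker inhibition of growth, not stronger. Its full size cannot be read from a value at the limit: the limit of > 100000 nM in this assay, at which 1 of the 4 values shown sits.

The compounds shown leave open whether 5-methylthiophen-2-yl would point the same way with the 4-chlorobenzyl or 4-fluorobenzyl group on the sulfur. They also leave open how an unsubstituted thiophen-2-yl, or a thiophene carrying a methoxy group or a carboxylic acid in place of the methyl, would read in this assay.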